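This account rests on a few compounds, and the source may have more. Where it says the series, first, only, none or still open, it means among the compounds named here.

Measured compounds:
compound 1 `Cc1nc(N)sc1CCCN/C(N)=N/C(=O)NC(C)c1ccc(Br)cc1` — 55 nM
compound 2 `Cc1nc(N)sc1CCCN/C(N)=N/C(=O)NC(C)c1ccc(Cl)cc1` — 24.6 nM
compound 3 `Cc1nc(N)sc1CCCN/C(N)=N/C(=O)NC(C)c1ccco1` — 9.77 nM

In a functional assay on Right cardiac atrium for agonist activity at histamine H2 receptor (Cavia porcellus), with a stated time of 30 min, in the presence of a further agent that is not named here (on this read-out higher numbers stand for an effect only at larger amounts of compound and lower numbers for an effect already at smaller amounts), compound 3 gives the lowest of the three numbers; the steps that lead there are a 2.5-fold lower number from compound 2 to compound 3 (0.40 log units; beyond the scatter) and a 5.6-fold lower number from compound 1 to compound 3 (0.75 log units; beyond the scatter), both beyond the scatter.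

Compound 4 `Cc1nc(N)sc1CCCN/C(N)=N/C(=O)NC(C)c1cccc(F)c1` differs from compound 3 by 3-fluorophenyl in place of furan-2-yl on a saturated chain carbon bound to an amide-type nitrogen and a saturated chain carbon. For the measured compounds named here, the steps that bear on this are the two aryl-to-furan exchanges, a 5.6-fold lower number from compound 1 to compound 3 (0.75 log units; beyond the scatter) and a 2.5-fold lower number from compound 2 to compound 3 (0.40 log units; beyond the scatter), which ran toward lower numbers; the reverse exchange, back to a substituted phenyl, is therefore expected to raise the number in this assay by a modest step, about a 2.6-fold higher number from compound 3 to compound 4 (0.41 log units; beyond the scatter). Compound 4 is expected at 25 nM, range 10 nM to 70 nM.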

Compound 4, half-maximal effective concentration: 26.3 nM
Compound 4: middle estimate off by 1.1-fold (0.02 log units), on the low side; the measured number falls inside the stated range.
By their numbers in this assay, from the lowest: compound 3; then compounds 2 and 4 (each within the scatter of the next); then compound 1.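

The advantage of furan-2-yl at this saturated chain carbon extends to a third substituted phenyl, 3-fluorophenyl (a 2.7-fold higher number from compound 3 to compound 4 (0.43 log units; beyond the scatter)) and is not confined to the two 4-halophenyl groups. Among the phenyls, 3-fluorophenyl and 4-chlorophenyl cannot be separated (a 1.1-fold higher number from compound 2 to compound 4 (0.03 log units; within the scatter)), whereas 3-fluorophenyl and 4-bromophenyl can (a 2.1-fold lower number from compound 1 to compound 4 (0.32 log units; beyond the scatter)), although these exchanges alter both the halogen and its ring position. No available evidence explains these differences.

Going by these compounds, it remains open whether thiophen-2-yl or cyclohexyl at this carbon would track with furan-2-yl or with the substituted phenyls.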